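Methyl on the benzyl ring of a sulfonylguanidine cytotoxin

The source may report more compounds than this note shows. Statements on the series, on what has been measured and on what is new or still open speak of the compounds shown alone.

Measured so far:
Compound 1, `Cc1cc(S(=O)(=O)/N=C(\N)n2nccc2-c2ccccc2)c(SCc2ccccc2)cc1Cl`, gives 5000 nM in a functional assay on HeLa cells (Homo sapiens) for cytotoxicity, read by MTT assay, with a stated time of 72 h; a lower number here means a stronger inhibitor, a higher number a weaker inhibitor.
Compound 2, `Cc1cc(-c2ccccc2)n(/C(N)=N/S(=O)(=O)c2cc(C)c(Cl)cc2SCc2ccccc2)n1`, gives 5000 nM.
Compound 3, `Cc1cc(-c2ccccc2)n(/C(N)=N/S(=O)(=O)c2cc(C)c(Cl)cc2SCc2cccc(Cl)c2)n1`, gives 8000 nM.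

Compound 1 stands level with compound 2, the two of them together holding the lowest numbers of the three; the step of no change at the digits printed from compound 1 to compound 2 (within the scatter) lies within the scatter, and the step of a 1.6-fold higher number from compound 2 to compound 3 (0.20 log units; within the scatter) does too. Compound 4, `Cc1ccc(CSc2cc(Cl)c(C)cc2S(=O)(=O)/N=C(\N)n2nccc2-c2ccccc2)cc1`, differs from compound 1 only in the benzylsulfanyl arm: methyl in place of hydrogen on an aromatic carbon. Both measured steps are small substituent swaps on aromatic carbons, and neither moved the number beyond the scatter, so the same is expected here, with no direction beyond noise. Compound 4 is therefore estimated at 5000 nM, within 2500 nM to 10000 nM, a step of no change at the digits printed from compound 1 to compound 4 (within the scatter).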

Compound 4, half-maximal inhibitory concentration: 17000 nM
Compound 4: the middle estimate sits 3.4-fold (0.53 log units) below what was measured, outside the stated range (above it).
By their numbers in this assay, from the lowest: compounds 1, 2 and 3 (each within the scatter of the next); then compound 4.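

Going by these compounds alone, putting a methyl on the benzyl ring, going from benzylsulfanyl to (4-methylbenzyl)sulfanyl, gives the first single change here to pass beyond the scatter (a 3.4-fold higher number from compound 1 to compound 4 (0.53 log units; beyond the scatter)), in the direction of a weaker inhibitor in this assay. So this place on the ring responds to the addition of a single carbon. Nothing available gives a reason for the rise.

The compounds shown leave open whether the rise is specific to methyl or would also follow from a fluoro, a methoxy or an amine at this place.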